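Fluoro to methoxy: what to expect of compound 3

This account rests on a few compounds, and the source may have more. Where it says the series, first, only, none or still open, it means among the compounds named here.

Compound 1 `O=C(CN1CCN(C(=O)c2ccc(Br)cc2)CC1)N1CCN(CCCc2c[nH]c3ccc(F)cc23)CC1` gives 47400 nM
Compound 2 `O=C(CN1CCN(C(=O)c2cccc(Cl)c2)CC1)N1CCN(CCCc2c[nH]c3ccc(F)cc23)CC1` gives 59800 nM

For the measured compounds named here, in an ADME assay on SH-SY5Y cells (Homo sapiens) for cytotoxicity, read by MTT assay, with a stated time of 72 h (on this read-out lower numbers stand for stronger inhibition and higher numbers for weaker inhibition), compound 1 stands level with the only other measured compound. Going by the values given here, the single measured step is a 1.3-fold higher number from compound 1 to compound 2 (0.10 log units; within the scatter), with 3-chlorophenyl in place of 4-bromophenyl on a carbonyl carbon.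

Compound 3 `COc1ccc2[nH]cc(CCCN3CCN(C(=O)CN4CCN(C(=O)c5ccc(Br)cc5)CC4)CC3)c2c1` keeps the rest of compound 1 and differs in one group: methoxy in place of fluoro on an aromatic carbon. Among the compounds with values here, no measured step touches this group. Within the data shown here, the one available step lies elsewhere in the molecule, so it bears only indirectly, and it offers no reason to expect a shift in either direction. The expected change is a 1.1-fold higher number from compound 1 to compound 3 (0.02 log units; within the scatter), no step beyond the scatter. For compound 3 the estimated value is 50000 nM, with an expected range from 24000 nM to 100000 nM.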

Compound 3, half-maximal inhibitory concentration: 150000 nM
Estimate against measurement, compound 3: 3.0-fold (0.48 log units) below, outside the stated range (above it).
By their numbers in this assay, from the lowest: compounds 1 and 2 (each within the scatter of the next); then compound 3.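

In this assay the change from 5-fluoro-1H-indol-3-yl to 5-methoxy-1H-indol-3-yl gives a 3.2-fold higher number from compound 1 to compound 3 (0.50 log units; beyond the scatter) and so moves the read-out towards weaker inhibition. The only earlier step, a 1.3-fold higher number from compound 1 to compound 2 (0.10 log units; within the scatter), lay elsewhere in the molecule and stayed within the scatter, so this aromatic carbon is the first place among these compounds where a single replacement separates two numbers. Nothing measured here explains the shift.

The compounds shown rest on one replacement at this carbon, so they leave open how a hydroxy, chloro or ethoxy group would read there. They also leave open whether methoxy in place of fluoro would produce a similar step with the 3-chlorophenyl group of compound 2 in place of the 4-bromophenyl group.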